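Trimming the hydroxy chain on a pyrazole urea

This account rests on a few compounds, and the source may have more. Where it says the series, first, only, none or still open, it means among the compounds named here.

In a functional assay on cells (Neutrophil, Homo sapiens) for inhibition, with a stated time of 10 min (a lower number here means a stronger inhibitor, a higher number a weaker inhibitor), compound 2, with the structure `CCCC(O)Cn1ncc(C(=O)OCC)c1NC(=O)NC(C)C`, gives 20 nM. Compound 3, drawn as `CCOC(=O)c1cnn(CC(O)CC)c1NC(=O)Nc1ccccc1F`, gives 120 nM in this assay, a higher number than compound 2 by a margin beyond the usual scatter, so compound 2 stands as the lower of the two numbers on record. Compound 1, with the structure `CCOC(=O)c1cnn(CC(C)O)c1NC(=O)Nc1ccc(F)cc1`, is reported in this assay only as a limit, > 10 nM, and not as a number; (the limit of > 10 nM in this assay, at which 1 of the 3 values shown sits).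

Compound 4, whose structure is `CCOC(=O)c1cnn(C)c1NC(=O)NC(C)C`, has not yet been measured in this assay. It differs from compound 2 in one place: hydrogen in place of 1-hydroxybutyl on a saturated chain carbon bound to an aromatic nitrogen. Among the measured compounds shown here, no measured pair isolates this change, so the size of the step is unknown. The expectation is that removing the 1-hydroxybutyl part costs some potency, the step from compound 2 to compound 4 being estimated as a 3.0-fold higher number from compound 2 to compound 4 (0.48 log units; beyond the scatter) in this assay. Compound 4 is therefore expected to give about 60 nM, in a range from 15 nM to 300 nM.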

Compound 4, half-maximal inhibitory concentration: 77 nM
For compound 4 the middle estimate is 1.3-fold (0.11 log units) below the measured one; the measured number falls inside the stated range.
By their numbers in this assay, from the lowest: compound 2; then compounds 4 and 3 (each within the scatter of the next).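

Cutting the 1-hydroxybutyl part away, so that 2-hydroxypentyl becomes methyl, gives a 3.9-fold higher number from compound 2 to compound 4 (0.59 log units; beyond the scatter) in this assay, and this is the first pair shown that differs in one place. The position therefore responds to the change, yet the hydroxy chain is not required for activity, since compound 4 keeps a measurable inhibitory value with only a methyl group there. Nothing measured here accounts for the size of this step.

The compounds shown leave open how much of the step belongs to the hydroxy group and how much to the length of the chain, a question that a plain pentyl group on the core of compound 2 would address. From the compounds shown here alone, how an amine or a carboxylic acid in place of that hydroxy group would fare also remains open.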